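The compounds below may be only part of what the source reports. "The series", "measured", "known", "first", "only" and "open" are said of these compounds alone.

The question here is antiproliferative activity in a functional assay on PC-3 cells (Homo sapiens) for antiproliferative activity, read by MTT assay, with a stated time of 48 h; a higher number here means a weaker inhibitor, a lower number a stronger inhibitor. Compound 1 `Cc1cnc(Nc2ccc(Cl)cc2)nc1Nc1nc2ccccc2s1` carries a chloro group. In this assay compound 1 gives > 50000 nM, which is a limit of the assay and not a number. Compound 1 therefore stands at the weak end of what has been measured so far. Compound 2 `Cc1ccc2nc(Nc3ccnc(Nc4ccc(S(C)(=O)=O)cc4)n3)sc2c1` is built from similar pieces joined in a different way. In this assay compound 2 gives > 50000 nM, again a limit rather than a number. Going by the values given here, compound 3 `Cc1ccc2nc(Nc3nc(Nc4ccc(S(N)(=O)=O)cc4)ncc3C)sc2c1` carries a sulfonamide, and in this assay compound 3 gives 2710 nM, the only numbered value among the three. Two of the three values sit at the same point, namely (the limit of > 50000 nM in this assay, at which 2 of the 3 values shown sit).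

Compound 4 `Cc1cnc(Nc2ccc(S(C)(=O)=O)cc2)nc1Nc1nc2ccccc2s1` is compound 1 with a single change: methylsulfonyl in place of chloro on an aromatic carbon. The new group enters on an aromatic carbon of a six-membered aromatic ring of carbon only, para to a large group. Compound 2 also carries a methylsulfonyl and gives > 50000 nM, a limit. The expected step is small, an at least 1.1-fold lower number from compound 1 to compound 4 (0.04 log units; that floor lies within the scatter), not clearly beyond the scatter. Compound 4 is expected to give 45000 nM, within 10000 nM to 200000 nM, with a fair chance that only a limit is reported.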

Compound 4, half-maximal inhibitory concentration: > 50000 nM
Compound 4 ended at the assay's limit; the forecaster's own chance of this, stated with the estimate: 60%; middle value at least 1.1-fold (0.04 log units) away from the limit.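

Going by these compounds alone, compound 1 and compound 4 both end at a limit in this assay and not at a number, so no step between them can be read. Most values now sit at one point: the limit of > 50000 nM in this assay, at which 3 of the 4 values shown sit. Still open, going by these compounds, is whether methylsulfonyl in place of chloro on the aromatic carbon changes the activity at all.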